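Swapping Nitro for Chloro on an Aryl Amide

This account rests on a few compounds, and the source may have more. Where it says the series, first, only, none or still open, it means among the compounds named here.

Compound 1, `O=C(Nc1ccc([N+](=O)[O-])cc1OCc1ccccc1)c1ccccc1`, in an assay on SK-BR-3 cells for inhibition of Aromatase (Homo sapiens) (a lower number here means a stronger inhibitor, a higher number a weaker inhibitor), reports a limit: > 25000 nM.
Compound 2, `CC(=O)Nc1ccc([N+](=O)[O-])cc1OCc1ccccc1`, in this assay gives 1180 nM.
Compound 3, `O=C(Nc1ccc([N+](=O)[O-])cc1OCc1ccccc1)c1ccc(Cl)c([N+](=O)[O-])c1`, in this assay reports a limit: > 25000 nM.

Compound 3 stands at the edge of what this assay can report: its value is a limit, not a number, and (the limit of > 25000 nM in this assay, at which 2 of the 3 values shown sit). Compound 4, `O=C(Nc1ccc([N+](=O)[O-])cc1OCc1ccccc1)c1ccc(Cl)c(Cl)c1`, differs from compound 3 in one place: chloro in place of nitro on an aromatic carbon.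

Two measured steps can be read. The step of an at least 21-fold lower number from compound 1 to compound 2 (1.32 log units; beyond the scatter) and the step of an at least 21-fold higher number from compound 2 to compound 3 (1.32 log units; beyond the scatter) both separate the methyl amide from the two aryl amides, which sit at the limit. The step that the two limits leave unreadable from compound 1 to compound 3 cannot be sized, since both ends are limits. Compound 4 keeps an aryl amide, so its reading is expected to stay near the limit. The step that the limit leaves unreadable from compound 3 to compound 4 is the expected one, not beyond the scatter. Compound 4 is expected to show 30000 nM, with a range from 8000 nM to 100000 nM.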

Compound 4, half-maximal inhibitory concentration: > 25000 nM
Compound 4: only a limit was reported; the forecaster's own chance of this, stated with the estimate: 75%; the middle value does not contradict the limit.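

In this assay compound 4 gives > 25000 nM as a limit and not a number. Chloro in place of nitro at this position therefore leaves the aryl amide at the limit, so a 3,4-dichlorophenyl amide joins the two aryl amides already there, and the step of an at least 21-fold higher number from compound 2 to compound 4 (1.32 log units; beyond the scatter) repeats the gap to the methyl amide, while the steps among compounds 1, 3 and 4 cannot be read. The limit now holds most of the compounds shown: the limit of > 25000 nM in this assay, at which 3 of the 4 values shown sit.

From the compounds shown here alone, how far nitro and chloro differ at this position stays open, as neither reading is a number. Also open, going by these compounds, is whether a longer chain such as ethyl or propyl on the carbonyl carbon, in place of methyl, would give a readable value in this assay or would reach the limit as well.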